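A few compounds are considered here, and "the series" means these few. Any claim that something is new, unique, unknown or untested is made for them only; others in the source may bear on it.

Measured in a functional assay on SK-N-SH cells (Homo sapiens) for inhibition, read by MTT assay, with a stated time of 72 h, tested at 50 uM; a lower number here means less inhibition of growth, a higher number more inhibition of growth at the concentration tested:

Compound 1 `C=CCc1ccc(OCc2cn(-c3ccc(C#N)cc3)nn2)c(O)c1`: 62.5%
Compound 2 `C=CCc1ccc(OCc2cn(-c3ccccc3CO)nn2)c(O)c1`: 87.1%
Compound 3 `C=CCc1ccc(OCc2cn(-c3cccc(C#N)c3)nn2)c(O)c1`: 78.8%

Compound 3, at 78.8%, sits close to the top of this small set. The numbers show a number 8.3 percentage points lower from compound 2 to compound 3 (within the scatter), so it cannot be separated from compound 2. They also show a number 16.3 percentage points higher from compound 1 to compound 3 (beyond the scatter), which places it clearly clear of compound 1.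

The next compound is compound 4 `C=CCc1ccc(OCc2cn(-c3ccc(Br)cc3)nn2)c(O)c1`, which has 4-bromophenyl in place of 3-cyanophenyl on an aromatic nitrogen. Among the measured compounds shown here, no measured compound carries 4-bromophenyl, so the bromine itself has no direct precedent here. For the measured compounds named here, the nearest guide is the one pair that compares the two numberings of the same group, a number 16.3 percentage points higher from compound 1 to compound 3 (beyond the scatter). Going by the values given here, compound 1, the only measured compound with a group at the 4 position of the phenyl, has the lowest number that is clearly separated from the others. The step of a number 24.6 percentage points higher from compound 1 to compound 2 (beyond the scatter) shows that changes at this place can be of modest size. This rests on a single pair, and it sets no rule. A modest move to a lower number in this assay is therefore expected, perhaps no larger than the scatter. The estimated step is a number 8.8 percentage points lower from compound 3 to compound 4 (within the scatter). For compound 4 the expected value is 70%, with an estimated range from 55% to 85%.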

Compound 4, percent growth inhibition at one concentration: 61.7%
Compound 4: the middle estimate sits 8.3 percentage points above what was measured, and the stated range covers the measured number.
By their numbers in this assay, from the lowest: compounds 4 and 1 (each within the scatter of the next); then compounds 3 and 2 (each within the scatter of the next).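

Compound 4 adds a second group on the phenyl ring to the comparison, and in this assay exchanging cyano for bromo on that ring leaves no difference that can be read, with a number 0.8 percentage points lower from compound 1 to compound 4 (within the scatter). The 4-bromophenyl and 4-cyanophenyl compounds therefore form a pair that stands apart from the other two compounds, with a number 17.1 percentage points lower from compound 3 to compound 4 (beyond the scatter) and a number 25.4 percentage points lower from compound 2 to compound 4 (beyond the scatter), so among these four compounds the named 4-substituted phenyl groups go with the lower numbers, and no compound here goes against this. No supporting measurement bears on why these numbers fall as they do.

The step to compound 4 from the 3-cyanophenyl compound changes both the group and its numbering at once, so the compounds shown cannot divide that step between the two changes, and the 2-(hydroxymethyl)phenyl compound has no counterpart with the hydroxymethyl group numbered differently. From the compounds shown here alone, it also remains open whether a phenyl ring carrying an amine or a carboxylic acid would fall with the 4-bromophenyl and 4-cyanophenyl pair or with the other two compounds.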